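Swapping cyano for fluoro at constant clearance

The source may hold more compounds than are shown below. What is called first, only, known or untested is meant among the compounds shown, and "the series" means these compounds.

Measured so far in an ADME assay on liver for metabolic stability, with Liver microsome (Homo sapiens) as the target, using microsomes (a higher number here means faster removal of the compound, a lower number slower removal), are three compounds
compound 1 `O=C(Nc1cc(-c2ccccn2)n[nH]1)N1CCC(c2cccc(F)c2)CC1` gives 25.3 mL.min-1.g-1
compound 2 `N#Cc1ccc(C2CCN(C(=O)Nc3cc(-c4ccccn4)n[nH]3)CC2)cc1` gives 25.3 mL.min-1.g-1
compound 3 `O=C(Nc1cc(-c2ccccn2)n[nH]1)N1CCN(c2ccc(F)cc2)CC1` gives 30.8 mL.min-1.g-1

Compound 2 stands level with compound 1, and compound 3 lies within the scatter of both. The change from compound 2 to compound 4 `O=C(Nc1cc(-c2ccccn2)n[nH]1)N1CCC(c2ccc(F)cc2)CC1` is fluoro in place of cyano on an aromatic carbon and amounts to fluoro in place of cyano on an aromatic carbon. Going by the values given here, one measured step bears on it, namely no change at the digits printed from compound 1 to compound 2 (within the scatter) with 4-cyanophenyl in place of 3-fluorophenyl on a saturated ring carbon. That step stayed within the scatter, so no step beyond the scatter is expected in this assay in either direction. The expected size is a 1.0-fold higher number from compound 2 to compound 4 (0.01 log units; within the scatter) in this estimate. For compound 4 the estimated value is 26 mL.min-1.g-1 with an expected range from 17 mL.min-1.g-1 to 39 mL.min-1.g-1.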

Compound 4, intrinsic clearance in microsomes: 42.5 mL.min-1.g-1
For compound 4 the middle estimate is 1.6-fold (0.21 log units) below the measured one, and the stated range ends below it.
By their numbers in this assay, from the lowest: compounds 1, 2, 3 and 4 (each within the scatter of the next).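

In this assay, cyano and fluoro on an aromatic carbon para to a large group are now compared directly, and the exchange gives a 1.7-fold higher number from compound 2 to compound 4 (0.23 log units; within the scatter) and so stays inside the scatter. The 4-fluorophenyl in place of 3-fluorophenyl gives a 1.7-fold higher number from compound 1 to compound 4 (0.23 log units; within the scatter) and likewise stays inside it, so the place of the fluoro makes no readable difference here. No measurement at hand explains these numbers. As far as these compounds go, whether an amine or a carboxylic acid on that aromatic carbon would also stay inside the scatter remains open.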